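The source may hold more compounds than are shown below. What is called first, only, known or untested is meant among the compounds shown, and "the series" means these compounds.

Working notes on the series.

Three compounds carry a measurement in an assay on isolated protein for binding affinity to leukotriene B4 receptor 1 (Homo sapiens), tested at 1 uM; on this read-out higher numbers stand for more inhibition at the one concentration tested (going by the name of the read-out) and lower numbers for less inhibition. Compound 1 `CC(=O)c1cc(C(C)=O)c(OCCCCC#N)cc1O` gives 0%. Compound 2 `C=CCc1cc(C(C)=O)c(O)cc1OCCCCC#N` gives 57%, the highest of the three numbers. Compound 3 `C=CCc1cc(C(C)=O)c(O)cc1OCCCCCC(=O)N(C)C` gives 54%. The two measured steps are a number 57 percentage points higher from compound 1 to compound 2 (beyond the scatter) and a number 3 percentage points lower from compound 2 to compound 3 (within the scatter); the step from compound 2 to compound 3 lies within the scatter, so compound 2 and compound 3 are not ordered against each other.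

Compound 4 `C=CCc1ccc(O)cc1OCCCCC#N` has not been measured. The change from compound 2 is hydrogen in place of acetyl on an aromatic carbon. Neither measured step matches this change: the large step from compound 1 to compound 2 exchanged acetyl for allyl rather than removing it, and the step from compound 2 to compound 3 touched the chain only. What the data show is that one acetyl removed in favour of allyl raised the number strongly, while the remaining acetyl has never been varied. A moderate drop in this assay is expected, with wide uncertainty, so that compound 4 is estimated at 35%, between 5% and 65%. The step this estimate means is a number 22 percentage points lower from compound 2 to compound 4 (beyond the scatter).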

Compound 4, a percentage reported as inhibition, at one concentration (the size of the read-out at that concentration, not a potency): 9%
Compound 4: the middle estimate sits 26 percentage points above what was measured, within the range that was stated.
By their numbers in this assay, from the lowest: compounds 1 and 4 (each within the scatter of the next); then compounds 3 and 2 (each within the scatter of the next).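

In this assay, the acetyl that stayed constant across compounds 2 and 3 is now shown to count: hydrogen in its place, on the aromatic carbon ortho to a hydroxy group, gives a number 48 percentage points lower from compound 2 to compound 4 (beyond the scatter). The gain seen in a number 57 percentage points higher from compound 1 to compound 2 (beyond the scatter) therefore does not rest on allyl alone, since compound 4 keeps the allyl group and the nitrile chain and still loses most of the number held by compound 2. Nothing measured here explains why removing this acetyl has so large an effect.

The compounds shown leave open whether propanoyl, methyl or a carboxylic acid on this carbon would hold the number of compound 2. As far as these compounds go, it also remains open whether removing the acetyl from compound 3, with its dimethylamide chain, would cost as much.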